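Carbonyl substituent variation in a Substance-P receptor series

The source may hold more compounds than are shown below. What is called first, only, known or untested is meant among the compounds shown, and "the series" means these compounds.

compound 1 `CC(C)C(=O)N1C[C@@H](O[C@H](C)c2cc(C(F)(F)F)cc(C(F)(F)F)c2)[C@H](c2ccc(F)cc2)C1`: 0.15 nM
compound 2 `C[C@@H](O[C@@H]1CN(C(=O)[C@@H]2COC(=O)N2)C[C@H]1c1ccc(F)cc1)c1cc(C(F)(F)F)cc(C(F)(F)F)c1`: 0.34 nM
compound 3 `CC(C)NC(=O)N1C[C@@H](O[C@H](C)c2cc(C(F)(F)F)cc(C(F)(F)F)c2)[C@H](c2ccc(F)cc2)C1`: 0.06 nM

In an assay on CHO cells for displacement of a labelled ligand from Substance-P receptor (Homo sapiens) (on this read-out lower numbers stand for stronger inhibition and higher numbers for weaker inhibition), compound 1 stands second highest of the three numbers; the nearest step is a 2.3-fold higher number from compound 1 to compound 2 (0.36 log units; beyond the scatter), the furthest a 2.5-fold lower number from compound 1 to compound 3 (0.40 log units; beyond the scatter). Compound 4 `C[C@@H](O[C@@H]1CN(C(=O)NCc2cn[nH]n2)C[C@H]1c1ccc(F)cc1)c1cc(C(F)(F)F)cc(C(F)(F)F)c1` is the next member of the series. (((2H-1,2,3-triazol-4-yl)methyl)amino in place of isopropyl on a carbonyl carbon). The measured step that bears on this change is a 2.5-fold lower number from compound 1 to compound 3 (0.40 log units; beyond the scatter), where an amino-linked group likewise entered on the carbonyl carbon; a 5.7-fold lower number from compound 2 to compound 3 (0.75 log units; beyond the scatter) points the same way. Going by the values given here, no measured step covers the ((2H-1,2,3-triazol-4-yl)methyl) part itself. A modest lower number is therefore expected, a 1.9-fold lower number from compound 1 to compound 4 (0.27 log units; within the scatter). Compound 4 is estimated at 0.08 nM, within a range of 0.03 nM to 0.3 nM.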

Compound 4, half-maximal inhibitory concentration: 0.58 nM
The estimate for compound 4 lay 7.3-fold (0.86 log units) below the measured number; the whole stated range lies below it.
By their numbers in this assay, from the lowest: compound 3; then compound 1; then compounds 2 and 4 (each within the scatter of the next).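

In this assay an amino link on the carbonyl carbon brings no gain of its own: what it carries decides, as (2H-1,2,3-triazol-4-yl)methyl on the amide-type nitrogen gives a clear loss (a 9.7-fold higher number from compound 3 to compound 4 (0.99 log units; beyond the scatter)) and the whole change gives a smaller one (a 3.9-fold higher number from compound 1 to compound 4 (0.59 log units; beyond the scatter)). Against 2-oxo-1,3-oxazolidin-4-yl the new group gives only a small difference (a 1.7-fold higher number from compound 2 to compound 4 (0.23 log units; within the scatter)), so those two stand level. Nothing available accounts for the loss. The compounds shown do not separate the triazole ring from its methyl link; benzylamino or cyclopropylmethylamino on the same carbonyl carbon would bear on that.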